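Swapping the thienyl arm of compound 1 for a dimethoxyphenyl

A few compounds are considered here, and "the series" means these few. Any claim that something is new, unique, unknown or untested is made for them only; others in the source may bear on it.

This account follows one change made to compound 1 `O=C(/C(=C\c1csc([N+](=O)[O-])c1)S(=O)(=O)c1ccc(Br)cc1)c1ccc(Br)cc1`. In a functional assay on DU-145 cells (Homo sapiens) for inhibition, read by trypan blue exclusion, with a stated time of 96 h (a lower number here means a stronger inhibitor of growth, a higher number a weaker inhibitor of growth), compound 1 gives 1000 nM. Compound 2 `O=C(O)c1ccc(C(=O)/C(=C\c2ccc(Cl)c([N+](=O)[O-])c2)SCc2ccccc2F)cc1` gives 1000 nM in this assay, level with compound 1 within the scatter, and the two share the lowest numbers of the three. For the measured compounds named here, compound 3 `Cc1ccc(CS(=O)(=O)/C(=C/c2sccc2C)C(=O)c2ccc(Cl)cc2)cc1` gives 25000 nM, the highest number, beyond the scatter from compound 1; no single-site step links it to compound 1.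

Compound 4 `COc1ccc(/C=C(\C(=O)c2ccc(Br)cc2)S(=O)(=O)c2ccc(Br)cc2)c(OC)c1` differs from compound 1 in one place: 2,4-dimethoxyphenyl in place of 5-nitrothiophen-3-yl on a double-bonded chain carbon bound to a double-bonded chain carbon. Going by the values given here, no pair of measured compounds shows this change, so its size is uncertain. He expects a moderate step upward, a 5.0-fold higher number from compound 1 to compound 4 (0.70 log units; beyond the scatter), because compound 3 gives 25000 nM with the only other arm without a nitro group. Compound 4 is estimated at 5000 nM, between 1500 nM and 20000 nM.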

Compound 4, concentration for 50% growth inhibition: 8000 nM
Beside the measured number, compound 4's estimate is 1.6-fold (0.20 log units) below it; the range from low to high includes it.
By their numbers in this assay, from the lowest: compounds 1 and 2 (each within the scatter of the next); then compound 4; then compound 3.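

With 2,4-dimethoxyphenyl in place of 5-nitrothiophen-3-yl, the shared core shows an 8.0-fold higher number from compound 1 to compound 4 (0.90 log units; beyond the scatter) in this assay, so the arm at this position can shift growth inhibition on its own. For the compounds shown here, this is the first single-site step, and no measurement here explains its size.

Going by these compounds, it remains open whether the loss follows the nitro group, the thiophene ring or the methoxy groups. A nitrophenyl arm, or an amine in place of the nitro group on the thiophene, would help separate these.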